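The compounds below may be only part of what the source reports. "The series", "measured", "known", "first", "only" and "open" are said of these compounds alone.

In a functional assay on DU-145 cells (Homo sapiens) for inhibition, read by trypan blue exclusion, with a stated time of 96 h (on this read-out lower numbers stand for stronger inhibition of growth and higher numbers for weaker inhibition of growth), the two measured compounds read:
- compound 1 `Cc1ccc(CS/C(=C/c2ccc(F)c(C)c2)C(=O)c2ccc(Cl)cc2)cc1` gives 25000 nM
- compound 2 `Cc1ccc(C)c(/C=C(/Sc2ccc(Br)cc2)C(=O)c2ccc(Cl)cc2)c1` gives 10000 nM

Compound 2 holds the lower number of the pair at 10000 nM, and the gap to compound 1 lies beyond the scatter. These two compounds differ in more than one place, so no single change can be read from them.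

Compound 3 `Cc1ccc(CS/C(=C/c2cc(C)ccc2C)C(=O)c2ccc(Cl)cc2)cc1` follows from compound 2 with 4-methylbenzyl in place of 4-bromophenyl on a sulfur. The same 4-methylbenzyl sits on the sulfur of compound 1, which gives 25000 nM in this assay. On that single comparison, a modest move toward weaker inhibition of growth is expected, with wide uncertainty.

The expected change is a 1.8-fold higher number from compound 2 to compound 3 (0.26 log units; within the scatter).

For compound 3 the estimated value is 18000 nM, with an expected range from 7000 nM to 45000 nM.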

Compound 3, concentration for 50% growth inhibition: 10000 nM
Compound 3: middle estimate off by 1.8-fold (0.26 log units), on the high side, within the range that was stated.
By their numbers in this assay, from the lowest: compounds 2 and 3 (each within the scatter of the next); then compound 1.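

In this assay, 4-methylbenzyl in place of 4-bromophenyl on the sulfur gives no change at the digits printed from compound 2 to compound 3 (within the scatter), so with the 2,5-dimethylphenyl group held fixed, this position takes either group without a change beyond the scatter. With 4-methylbenzyl held on the sulfur, 2,5-dimethylphenyl in place of 4-fluoro-3-methylphenyl on the double-bonded chain carbon gives a 2.5-fold lower number from compound 1 to compound 3 (0.40 log units; beyond the scatter). No measurement available here explains either result.

On these data alone, both readings rest on a single pair each, so it remains open whether the sulfur position would hold its number with a longer chain in place of 4-methylbenzyl. An amine or a carboxylic acid on that ring is equally untested among the compounds shown.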